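Methyl in place of phenyl on the ring nitrogen

A few compounds are considered here, and "the series" means these few. Any claim that something is new, unique, unknown or untested is made for them only; others in the source may bear on it.

Compound 1 `Cc1nn(C(C)(C)C)c2nc(C(C)C)c(/C=C/[C@@H](O)C[C@@H](O)CC(=O)O)c(-c3ccc(F)cc3)c12`: 51.8%
Compound 2 `Cc1nn(Cc2ccccc2)c2nc(C(C)C)c(/C=C/[C@@H](O)C[C@@H](O)CC(=O)O)c(-c3ccc(F)cc3)c12`: 16.4%
Compound 3 `Cc1nn(-c2ccccc2)c2nc(C(C)C)c(/C=C/[C@@H](O)C[C@@H](O)CC(=O)O)c(-c3ccc(F)cc3)c12`: 3.3%

The three measured compounds share one core and differ only in the group on an aromatic nitrogen of the five-membered aromatic ring. In an in vivo functional assay on the whole organism for inhibition of 3-hydroxy-3-methylglutaryl-coenzyme A reductase (Rattus norvegicus), at a dose of 0.2 mg/kg by the oral route (on this read-out higher numbers stand for a stronger effect at the one dose given and lower numbers for a weaker effect), compound 3 gives 3.3%, the lowest of the three numbers. The nearest is compound 2, separated by a number 13.1 percentage points lower from compound 2 to compound 3 (beyond the scatter); the furthest is compound 1, separated by a number 48.5 percentage points lower from compound 1 to compound 3 (beyond the scatter).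

Compound 4 `Cc1nn(C)c2nc(C(C)C)c(/C=C/[C@@H](O)C[C@@H](O)CC(=O)O)c(-c3ccc(F)cc3)c12` is not yet measured. It differs from compound 3 as follows: methyl in place of phenyl on an aromatic nitrogen. For the measured compounds named here, two measured steps bear on this change. Going from tert-butyl to phenyl gave a number 48.5 percentage points lower from compound 1 to compound 3 (beyond the scatter), and going from benzyl to phenyl gave a number 13.1 percentage points lower from compound 2 to compound 3 (beyond the scatter). Both steps away from phenyl and toward an alkyl group on that nitrogen raised the number, and the small alkyl group in compound 1 gave the highest value. Compound 4 is therefore expected to show a rise of a number 26.7 percentage points higher from compound 3 to compound 4 (beyond the scatter) beyond the scatter. The estimate for compound 4 is 30%, within 5% to 60%.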

Compound 4, a percentage reported as inhibition, in the whole organism at one dose (the size of the read-out at that dose, not a potency): 41.1%
Estimate against measurement, compound 4: 11.1 percentage points below; the measured number falls inside the stated range.
By their numbers in this assay, from the lowest: compound 3; then compound 2; then compound 4; then compound 1.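

In this assay, methyl in place of phenyl on the aromatic nitrogen gave a number 37.8 percentage points higher from compound 3 to compound 4 (beyond the scatter), so a single carbon at this position restores much of the read-out lost with phenyl. Removing the phenyl from the saturated chain carbon of benzyl gave a number 24.7 percentage points higher from compound 2 to compound 4 (beyond the scatter), which extends the comparison to a second group that carries this ring. The read-out does not simply rise as the group gets smaller, since methyl in place of tert-butyl gave a number 10.7 percentage points lower from compound 1 to compound 4 (beyond the scatter) and leaves the two alkyl groups apart.

No evidence is available to explain these differences. Going by these compounds, it remains open how ethyl or isopropyl on this nitrogen would compare with methyl and tert-butyl, and whether a hydrogen or a hydroxyethyl chain there would hold the read-out.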